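The source may report more compounds than this note shows. Statements on the series, on what has been measured and on what is new or still open speak of the compounds shown alone.

Measured so far in a functional assay on A549 cells (Homo sapiens) for inhibition, read by sulforhodamine B assay, tested at 100 uM; on this read-out higher numbers stand for more inhibition of growth at the one concentration tested and lower numbers for less inhibition of growth:
compound 1, `COc1cc(C2CC(c3ccc(Br)cc3)=NN2C(C)=O)ccc1OCc1cn(Cc2ccc([N+](=O)[O-])cc2)nn1`, gives 17%
compound 2, `COc1cc(C2CC(c3ccccc3)=NN2C(C)=O)ccc1OCc1cn(Cc2ccc([N+](=O)[O-])cc2)nn1`, gives 11%

Among the measured compounds shown here, compound 2 holds the lowest of the two numbers in this assay, its only neighbour being compound 1. For the measured compounds named here, the single measured step, a number 6 percentage points lower from compound 1 to compound 2 (within the scatter), hydrogen in place of bromo on an aromatic carbon, lies within the scatter, so the two values cannot be told apart.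

Compound 3, `COc1ccc(C2=NN(C(C)=O)C(c3ccc(OCc4cn(Cc5ccc([N+](=O)[O-])cc5)nn4)c(OC)c3)C2)cc1`, has not yet been measured. It differs from compound 2 by methoxy in place of hydrogen on an aromatic carbon. Going by the values given here, the one measured step that bears on this change is the exchange of a small group for hydrogen on an aromatic carbon between compound 1 and compound 2, and that step, a number 6 percentage points lower from compound 1 to compound 2 (within the scatter), was within the scatter. Nothing else is known about how substituents on that ring move the growth inhibition. On this basis no step beyond the scatter is expected.

Compound 3 is therefore estimated at 13%, with a range from 0% to 30%. The expected step of a number 2 percentage points higher from compound 2 to compound 3 (within the scatter) is none beyond the scatter.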

Compound 3, percent growth inhibition at one concentration: 84%
Compound 3: the middle estimate sits 71 percentage points below what was measured, and the stated range ends below it.
By their numbers in this assay, from the lowest: compounds 2 and 1 (each within the scatter of the next); then compound 3.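

In this assay the position para to a large group on the six-membered aromatic ring now proves able to carry a large change: going from phenyl to 4-methoxyphenyl gives a number 73 percentage points higher from compound 2 to compound 3 (beyond the scatter) and the same place gives a number 67 percentage points higher from compound 1 to compound 3 (beyond the scatter) when methoxy stands in place of bromo. The values for hydrogen and bromo at this position could not be told apart, so the position does not respond to every replacement of hydrogen, and among the three groups shown only methoxy separates from the others, leaving compound 3 as the most active member of the set. Nothing available bears on why methoxy parts from hydrogen and bromo at this position.

From the compounds shown here alone, it stays open whether the gain is particular to methoxy or is shared by groups such as hydroxy, ethoxy, a dimethylamine or a carboxylic acid at the same place. Also open, going by these compounds, is how compound 3 behaves across a range of concentrations, since each reading here comes from a single concentration on one cell line.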